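Cyclopropyloxy to isobutyl on the carbonyl carbon of compound 1

The source may hold more compounds than are shown below. What is called first, only, known or untested is meant among the compounds shown, and "the series" means these compounds.

Two members of this series carry a number in a physicochemical assay for lipophilicity; on this read-out higher numbers stand for higher lipophilicity and lower numbers for lower lipophilicity. Compound 1 `COC(C)(C)CCCC(C)C/C=C/C(C)=C/C(=O)OC1CC1` gives 5.71 and stands lowest of the two. Within the data shown here, compound 2 `CC(/C=C/CC(C)CCCC(C)(C)C)=C\C(=O)OC(C)C` gives 7.56 in this assay, a number well beyond the scatter above compound 1; no single-point step links these two, so their values are read side by side only.

The step under consideration leads from compound 1 to compound 3 `COC(C)(C)CCCC(C)C/C=C/C(C)=C/C(=O)CC(C)C`, which has not been measured in this assay. The change is isobutyl in place of cyclopropyloxy on a carbonyl carbon. Cut one bond further out it reads cyclopropyloxycarbonyl to isobutylcarbonyl: one hydrogen-bond acceptor leaves and a four-carbon, ring-free group enters in its place.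

Among the measured compounds shown here, no measured pair shows this exact change, so its size is not known from the numbers. The step expected from compound 1 to compound 3 is a number 0.79 log units higher from compound 1 to compound 3 (beyond the scatter), upward and beyond the scatter, since the value of compound 1 in this assay is 5.71 and the shared core is otherwise kept. Compound 3 is therefore estimated at 6.5, within the range 6 to 7.1.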

Compound 3, partition coefficient: 6.02
Compound 3: middle estimate off by 0.48 log units, on the high side; low and high end bracket the measured number.
By their numbers in this assay, from the lowest: compound 1; then compound 3; then compound 2.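

With isobutyl in place of cyclopropyloxy on a carbonyl carbon, this assay gives the series its first measured single-point step, a number 0.31 log units higher from compound 1 to compound 3 (beyond the scatter), so this position now has a size attached to one change. Among these compounds, the step is small beside the spread of values printed for the series so far, and the shared core stays the same throughout, so it can be read as belonging to this one exchange of groups. Both groups hold the same number of heavy atoms, yet the three-membered ring and the hydrogen-bond acceptor leave together, and nothing measured here says why the number moves.

Among the compounds shown here, the single step cannot divide its size between loss of the ring and loss of the oxygen: an open-chain group such as isobutyloxy, or a cyclopropylmethyl group, on the same carbonyl carbon would separate the two. On these data alone, how far the read-out moves with a longer chain, an amine or a carboxylic acid at this position, and whether the step holds on another core, remains open.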